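Trifluoromethyl to dimethyl on the azepanone series

The source may hold more compounds than are shown below. What is called first, only, known or untested is meant among the compounds shown, and "the series" means these compounds.

Among the measured compounds shown here, in an in vitro ADME assay on microsomes (Homo sapiens) for pharmacokinetics (on this read-out higher numbers stand for fast clearance and lower numbers for slow clearance), compound 2 (`O=C(NC1CC1)c1ccc(CN(C2CC(C(F)(F)F)CCNC2=O)S(=O)(=O)c2ccc(Cl)cc2)cc1`) gives 19 mL.min-1.g-1, the lower of the two numbers so far, while compound 1 (`CC(C)C1CCNC(=O)C(N(Cc2ccc(C(=O)NC3CC3)cc2)S(=O)(=O)c2ccc(Cl)cc2)C1`) gives 51 mL.min-1.g-1. Compound 3 (`CC1(C)CCNC(=O)C(N(Cc2ccc(C(=O)NC3CC3)cc2)S(=O)(=O)c2ccc(Cl)cc2)C1`) is not yet measured. It carries 5,5-dimethyl-2-oxoazepan-3-yl in place of 2-oxo-5-(trifluoromethyl)azepan-3-yl on a sulfonamide nitrogen.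

For the measured compounds named here, only one measured step bears on this change: a 2.7-fold lower number from compound 1 to compound 2 (0.43 log units; beyond the scatter), a modest step with trifluoromethyl in place of isopropyl on a saturated ring carbon. The trifluoromethyl group leaves again in compound 3, but dimethyl is not the isopropyl of compound 1, so that step is only a partial guide. With one step to go on, the reverse direction is taken as the best available reading, with a size not exceeding the measured one. The expected move in this assay is therefore towards a higher number, and it is estimated as a 1.9-fold higher number from compound 2 to compound 3 (0.28 log units; within the scatter). For compound 3 the estimated value is 36 mL.min-1.g-1, with an expected range of 18 mL.min-1.g-1 to 70 mL.min-1.g-1.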

Compound 3, intrinsic clearance in microsomes: 45 mL.min-1.g-1
Estimate against measurement, compound 3: 1.3-fold (0.10 log units) below; the measured number falls inside the stated range.
By their numbers in this assay, from the lowest: compound 2; then compounds 3 and 1 (each within the scatter of the next).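

In this assay, a second group without fluorine now stands against the trifluoromethyl compound, and the step is a 2.4-fold higher number from compound 2 to compound 3 (0.37 log units; beyond the scatter) with 5,5-dimethyl-2-oxoazepan-3-yl in place of 2-oxo-5-(trifluoromethyl)azepan-3-yl on the sulfonamide nitrogen. The two alkyl-bearing rings cannot be separated on this read-out, with a 1.1-fold lower number from compound 1 to compound 3 (0.05 log units; within the scatter) for 5,5-dimethyl-2-oxoazepan-3-yl in place of 5-isopropyl-2-oxoazepan-3-yl, so swapping isopropyl for dimethyl makes no measurable difference here, and among these three compounds the lower number goes with trifluoromethyl alone. No supporting measurement is available to say what lies behind these numbers.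

Open, from the compounds shown here alone, is how other groups on the same ring carbon would read against trifluoromethyl and the two alkyl patterns, for example difluoromethyl, a single methyl, a hydroxyl or a nitrile, which would show whether the lower number is tied to trifluoromethyl itself. Also open, going by these compounds, is whether the step from trifluoromethyl to dimethyl keeps its size when the rest of the molecule changes, since all three compounds share the same remaining core.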